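A Second Methyl on the Aryl Ring of Compound 3

This account rests on a few compounds, and the source may have more. Where it says the series, first, only, none or still open, it means among the compounds named here.

Compound 1, `CN(C(=O)N1CC[C@H](n2cnc3cc(-c4ccc(Cl)cc4)sc3c2=O)C1)[C@H]1CCN(CC2CC2)C1`: 3 nM
Compound 2, `CN(C(=O)N1CC[C@H](n2cnc3cc(-c4ccc(Cl)cc4)sc3c2=O)C1)[C@H]1CCN(CC2CCCCC2)C1`: 50 nM
Compound 3, `Cc1ccc(-c2cc3ncn([C@H]4CCN(C(=O)N(C)[C@H]5CCN(C)C5)C4)c(=O)c3s2)cc1`: 15 nM

Of the compounds shown here, three share one core and have been measured in an assay on isolated protein for binding affinity to melanin-concentrating hormone receptor 1 (Homo sapiens); on this read-out lower numbers stand for stronger inhibition and higher numbers for weaker inhibition. Compound 1 gives 3 nM, compound 2 gives 50 nM, and compound 3 gives 15 nM. Compound 3 therefore stands second highest of the three numbers: its nearest neighbour is compound 2, and it sits furthest from compound 1, which shows the lowest number of the set.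

Within the data shown here, the single step measured so far, a 17-fold higher number from compound 1 to compound 2 (1.22 log units; beyond the scatter), concerns the group on a saturated chain carbon bound to the ring amine nitrogen, a part of the molecule far from the aryl ring. It does not touch the change now in question.

Compound 4, `Cc1ccc(-c2cc3ncn([C@H]4CCN(C(=O)N(C)[C@H]5CCN(C)C5)C4)c(=O)c3s2)c(C)c1`, differs from compound 3 by methyl in place of hydrogen on an aromatic carbon. In words, the 4-methylphenyl group becomes a 2,4-dimethylphenyl group. Among the measured compounds shown here, no measured pair shows what a change at this aromatic carbon does, so the direction cannot be read from the data, and a step of modest size either way remains possible.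

In the absence of a guiding step, compound 4 is expected to give 20 nM in this assay, with a range from 5 nM to 80 nM, which means an estimated step of a 1.3-fold higher number from compound 3 to compound 4 (0.12 log units; within the scatter).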

Compound 4, inhibition constant: 49 nM
For compound 4 the middle estimate is 2.5-fold (0.39 log units) below the measured one; measured number inside the range.
By their numbers in this assay, from the lowest: compound 1; then compound 3; then compounds 4 and 2 (each within the scatter of the next).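

Adding one methyl to an aromatic carbon ortho to a large group, which turns the 4-methylphenyl group into a 2,4-dimethylphenyl group, gives in this assay a 3.3-fold higher number from compound 3 to compound 4 (0.51 log units; beyond the scatter) and so moves toward weaker inhibition. This carbon of the aryl ring is therefore not a silent spot: one extra heavy atom here changes the read-out by more than repeat measurements would, and in this pair hydrogen gives the stronger inhibition of the two. Nothing available explains why the number rises.

The compounds shown leave open whether another small group at this same carbon, such as fluorine, chlorine or methoxy, would also raise the number, or whether the rise belongs to methyl alone. They also leave open whether the same added methyl would have a similar effect on a 4-chlorophenyl group, as carried by compound 1, or at the other carbons of the aryl ring, so this single pair cannot yet be read as a rule for the series.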